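Solubility across the aromatic-carbon substituent of the shared core

The source may hold more compounds than are shown below. What is called first, only, known or untested is meant among the compounds shown, and "the series" means these compounds.

Measured so far in a physicochemical assay for solubility, with a stated time of 18 h, at pH 7.4; on this read-out higher numbers stand for higher solubility and lower numbers for lower solubility:
- compound 1, `COc1ccc(F)cc1CNCCCNc1ccnc2cc(CC(C)C)ccc12`: 4200 nM
- compound 2, `COc1ccc(F)cc1CNCCCNc1ccnc2cc(Oc3ccc(C(C)(C)C)cc3)ccc12`: 14500 nM
- compound 3, `COc1ccc(F)cc1CNCCCNc1ccnc2cc(-c3ccc(F)cc3)ccc12`: 32000 nM

Compound 3 gives the highest of the three numbers in this assay . Its nearest neighbour is compound 2, and the step ran a 2.2-fold higher number from compound 2 to compound 3 (0.34 log units; beyond the scatter). Against compound 1 the step ran a 7.6-fold higher number from compound 1 to compound 3 (0.88 log units; beyond the scatter), the widest gap in the set; the remaining step, a 3.5-fold higher number from compound 1 to compound 2 (0.54 log units; beyond the scatter), sits between the two.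

Compound 4, `COc1ccc(F)cc1CNCCCNc1ccnc2cc(CC3CCCCC3)ccc12`, is not yet measured. It differs from compound 3 in one place: cyclohexylmethyl in place of 4-fluorophenyl on an aromatic carbon. Among the compounds with values here, the step that bears most directly on this is the one from compound 1 to compound 3, where a 4-fluorophenyl replaced isobutyl and the number rose; compound 4 moves back from the 4-fluorophenyl to a group with one six-membered non-aromatic ring of carbon only, resembling the isobutyl of compound 1 more than the aromatic ring of compound 3. A step downward, beyond the scatter, is therefore expected, on the order of a 6.4-fold lower number from compound 3 to compound 4 (0.81 log units; beyond the scatter). Compound 4 is estimated at 5000 nM in this assay , with a range from 1500 nM to 15000 nM.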

Compound 4, solubility: 4200 nM
Estimate against measurement, compound 4: 1.2-fold (0.08 log units) above, and the stated range covers the measured number.
By their numbers in this assay, from the lowest: compounds 1 and 4 (each within the scatter of the next); then compound 2; then compound 3.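

In this assay the cyclohexylmethyl group brings no separation from the open-chain isobutyl group, with no change at the digits printed from compound 1 to compound 4 (within the scatter), so closing the chain end into a non-aromatic ring of carbon only does not move the number at this position. Replacing the aromatic ring of 4-fluorophenyl with the non-aromatic ring of cyclohexylmethyl, at the same heavy-atom count, gives a 7.6-fold lower number from compound 3 to compound 4 (0.88 log units; beyond the scatter), and the change from 4-(tert-butyl)phenoxy gives a 3.5-fold lower number from compound 2 to compound 4 (0.54 log units; beyond the scatter). Across these four compounds, the two with an aromatic ring in this substituent therefore give higher numbers than the two without one, and none goes against that split.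

Nothing available accounts for the split. As far as these compounds go, it remains open whether it would hold for a substituent bearing an amine or a carboxylic acid, or for a cyclohexyl group bound directly to the aromatic carbon.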